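Moving the ring oxygen: compound 1 to compound 3

The compounds below may be only part of what the source reports. "The series", "measured", "known", "first", "only" and "open" are said of these compounds alone.

The series shares one core, carrying a hydroxyethyl-type branch on an aromatic carbon of the dichlorinated ring. For the measured compounds named here, compound 1 `Cc1cc(C)c(CN2CCc3c(Cl)cc([C@H](CO)[C@H]4CCOC4)c(Cl)c3C2=O)c(=O)[nH]1` is the most potent of the two compounds measured here, with 0.24 nM in an assay for inhibition of histone-lysine N-methyltransferase EZH2 variant Y641N (Homo sapiens), read by scintillation counting, with a stated time of 60 min, in the presence of a further agent that is not named here; a lower number here means a stronger inhibitor, a higher number a weaker inhibitor; no other compound in the set is stronger. Compound 2 `Cc1cc(C)c(CN2CCc3c(Cl)cc(C(CO)c4ccon4)c(Cl)c3C2=O)c(=O)[nH]1`, which bears an isoxazole in place of the saturated ring, was measured more than once in this assay, and compound 2 gives 360 nM; 24 nM (2 entries); the spread of those entries the several entries of compound 2 in this assay, 360 nM; 24 nM (2 entries) is itself wider than the usual scatter, so the reading for compound 2 is less settled.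

Compound 3 `Cc1cc(C)c(CN2CCc3c(Cl)cc([C@@H](CO)[C@@H]4CCCO4)c(Cl)c3C2=O)c(=O)[nH]1` is the untested member. It keeps every atom of compound 1, joined differently: a group of 8 heavy atoms (6 carbon, 2 oxygen; one five-membered non-aromatic ring with 1 hetero atom) in place of a group of 8 heavy atoms (6 carbon, 2 oxygen; one five-membered non-aromatic ring with 1 hetero atom), on an aromatic carbon. Going by the values given here, no measured pair in this set reports the effect of such a rearrangement, so the direction rests on expectation alone. A modest loss is expected, with the step from compound 1 to compound 3 estimated at a 4.2-fold higher number from compound 1 to compound 3 (0.62 log units; beyond the scatter). Compound 3 is therefore expected to give about 1 nM in this assay, within a range of 0.2 nM to 8 nM.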

Compound 3, inhibition constant: 135 nM
The estimate for compound 3 lay 140-fold (2.13 log units) below the measured number; measured number outside the range, above it.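

Read in this assay, the rearrangement produced a step of a 560-fold higher number from compound 1 to compound 3 (2.75 log units; beyond the scatter), although the leaving and entering groups match in every count printed for them: 8 heavy atoms, one five-membered non-aromatic ring with 1 hetero atom, 1 hydrogen-bond donor, 2 hydrogen-bond acceptors and 2 defined stereocentres. The earlier compounds shown here could not show this, since compound 2 differs from compound 1 in the ring itself, whereas here the same atoms are simply joined differently. At this aromatic carbon, then, the reading depends strongly on how the group is joined and not only on what it is made of, and nothing given here accounts for the size of this loss.

The compounds shown leave open how much of the loss belongs to the shifted ring oxygen and how much to the arrangement at the two stereocentres, since the two differ together in compound 3. They also leave open how an amine in place of the ring oxygen, or an open methoxyethyl chain in place of the ring, would read at this position.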